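Methyl-to-Fluoro Swaps on a Piperazine Isoxazole Series

The source may hold more compounds than are shown below. What is called first, only, known or untested is meant among the compounds shown, and "the series" means these compounds.

Measured so far:
compound 1, `Cc1cccc(COc2ccc(-c3cc(CN4CCN(Cc5ccc(C(F)(F)F)cc5)CC4)no3)cc2)c1`, gives 4000 nM;
compound 2, `Fc1cccc(COc2ccc(-c3cc(CN4CCN(Cc5ccc(C(F)(F)F)cc5)CC4)no3)cc2)c1`, gives 2500 nM;
compound 3, `Cc1cc(OCc2cccc(C#N)c2)ccc1-c1cc(CN2CCN(Cc3ccc(C(F)(F)F)cc3)CC2)no1`, gives 400 nM.

All three were tested in a functional assay on MCF7 cells (Homo sapiens) for antiproliferative activity, read by sulforhodamine B assay, with a stated time of 72 h; a higher number here means a weaker inhibitor, a lower number a stronger inhibitor. The step of a 1.6-fold lower number from compound 1 to compound 2 (0.20 log units; within the scatter) shows (fluoro in place of methyl on an aromatic carbon), a change whose place is meta to a large group. Compound 3 sits lowest of the three numbers, beyond the scatter from both others; how its core differs from that of compound 1 is not broken down here.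

Compound 4, `N#Cc1cccc(COc2ccc(-c3cc(CN4CCN(Cc5ccc(C(F)(F)F)cc5)CC4)no3)c(F)c2)c1`, has not yet been measured. It differs from compound 3 by fluoro in place of methyl on an aromatic carbon, the same kind of change as from compound 1 to compound 2, but at a place that is ortho to a large group and meta to a (3-cyanobenzyl)oxy group rather than meta to a large group. Because the earlier step of a 1.6-fold lower number from compound 1 to compound 2 (0.20 log units; within the scatter) stayed within the scatter, the step from compound 3 to compound 4 is expected to be small as well, about a 1.3-fold lower number from compound 3 to compound 4 (0.10 log units; within the scatter). Compound 4 is therefore estimated at 320 nM, likely between 120 nM and 900 nM.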

Compound 4, half-maximal inhibitory concentration: 1200 nM
Compound 4: middle estimate off by 3.8-fold (0.57 log units), on the low side; the measured number lies above the stated range.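

In this assay, fluoro in place of methyl on an aromatic carbon gives a 3.0-fold higher number from compound 3 to compound 4 (0.48 log units; beyond the scatter), making compound 4 the weaker inhibitor of this pair. Set beside the earlier swap, the same change does not carry over unchanged from one core to the other: the same change on two cores in this assay, a 1.6-fold lower number (0.20 log units; within the scatter) from compound 1 to compound 2 and a 3.0-fold higher number (0.48 log units; beyond the scatter) from compound 3 to compound 4, 4.8-fold (0.68 log units) apart, beyond the scatter of two such steps. This does not show why the two steps part, since the swaps lie on different cores and in different surroundings, and two pairs give no rule for other cores in the series.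

Still open, going by these compounds, is how chloro or methoxy, ortho to a large group, would compare with methyl and fluoro. Also open, on these data alone, is what this swap would do elsewhere on the core of compound 3.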